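The source may report more compounds than this note shows. Statements on the series, on what has been measured and on what is new or still open speak of the compounds shown alone.

Compound 1 `O=S(=O)(Oc1ccccc1)[C@H]1C[C@H]2O[C@@H]1C(c1ccc(O)cc1)=C2c1ccc(O)cc1`: > 100000 nM
Compound 2 `O=C(O)CCCCCCC(=O)Nc1ccc(C2=C(c3ccc(O)cc3)C3CC(S(=O)(=O)Oc4cccc5ccccc45)C2O3)cc1`: > 100000 nM
Compound 3 `O=C(CCCCCCC(=O)Nc1ccc(C2=C(c3ccc(O)cc3)C3CC(S(=O)(=O)Oc4cccc5ccccc45)C2O3)cc1)NO`: > 100000 nM

All three entries come from an ADME assay on Vero cells (Chlorocebus sabaeus) for inhibition, read by MTT assay, with a stated time of 72 h (on this read-out higher numbers stand for weaker inhibition and lower numbers for stronger inhibition), and each is a limit of the assay, not a number.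

Compound 2 therefore has no exact place on this scale, and its entry, > 100000 nM, is a limit. The other two entries are limits as well. Compound 4 `O=C(O)CCCCCCC(=O)Nc1ccc(C2=C(c3ccc(O)cc3)C3CC(S(=O)(=O)Oc4ccc(F)cc4)C2O3)cc1` has not yet been measured. It differs from compound 2 as follows: 4-fluorophenyl in place of naphthalen-1-yl on an oxygen. In words, this is 4-fluorophenyl in place of naphthalen-1-yl on an oxygen.

Among the measured compounds shown here, only one measured step is available, a step that the two limits leave unreadable from compound 2 to compound 3. It puts hydroxyamino in place of hydroxy on a carbonyl carbon, so it does not touch the group that changes here and gives no size to carry over. The broader picture is the limit of > 100000 nM in this assay, at which 3 of the 3 values shown sit. The expectation for compound 4 therefore starts from compound 2 and its limit of > 100000 nM. No shift beyond the scatter is expected in this assay, in either direction, so the expected change is a number no higher from compound 2 to compound 4 (the limit leaves the size open). The estimate for compound 4 is 100000 nM, with an expected range from 50000 nM to 200000 nM.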

Compound 4, half-maximal inhibitory concentration: > 100000 nM
Compound 4 gave a limit, no number; the forecaster's own chance of this, stated with the estimate: 85%; the middle value lies on the limit itself.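

In this assay, compound 2 and compound 4 both stand as limits of the assay, not as numbers, so the step between them cannot be read. The compounds shown leave open whether 4-fluorophenyl in place of naphthalen-1-yl on an oxygen changes the read-out at all, and how the four compounds would rank against one another.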